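From 1-Hydroxy-1-methylethyl to Carboxy on Compound 2

A few compounds are considered here, and "the series" means these few. Any claim that something is new, unique, unknown or untested is made for them only; others in the source may bear on it.

In an ADME assay on microsomes from liver (Rattus norvegicus) for metabolic stability (on this read-out lower numbers stand for a shorter-lived compound and higher numbers for a longer-lived compound), compound 1 `COc1cc(OCc2cccc(-c3cnc(OC)nc3)c2)c2cc(-c3cn4nc(OC)sc4n3)oc2c1` gives 1.03 h and compound 2 `COc1cc(OCc2csc(-c3ccc(C(C)(C)O)cc3)n2)c2cc(-c3cn4nc(OC)sc4n3)oc2c1` gives 1.15 h on the same read-out, so these two stand within the usual scatter of each other. Compound 3 `COc1cc(OCc2csc(-c3ccc(C(=O)O)cc3)n2)c2cc(-c3cn4nc(OC)sc4n3)oc2c1` differs from compound 2 in one place, with carboxy in place of 1-hydroxy-1-methylethyl on an aromatic carbon. Among the measured compounds shown here, no measured pair shows this change, so in this assay only a small upward move is expected, with a 1.3-fold higher number from compound 2 to compound 3 (0.12 log units; within the scatter) estimated to stay within the scatter. Compound 3 is expected at 1.5 h with an estimated range of 0.7 h to 3.2 h on this read-out.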

Compound 3, half-life: > 2 h
Compound 3: only a limit was reported (the forecaster's own chance of this, stated with the estimate: 15%); middle value at least 1.3-fold (0.12 log units) from the limit.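

In this assay, carboxy in place of 1-hydroxy-1-methylethyl on this aromatic carbon gives an at least 1.7-fold higher number from compound 2 to compound 3 (0.24 log units; that floor lies within the scatter). So this position takes a carboxy group with no shortening of the half-life, although that floor alone does not prove a real rise. The value for compound 3 is a limit and not a number: the limit of > 2 h in this assay, at which 1 of the 3 values shown sits.

As far as these compounds go, how far the half-life of compound 3 truly reaches stays open. Also open, from the compounds shown here alone, is whether an amide or a sulfonamide on the same carbon would behave like carboxy.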